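One Group Swapped for Acetyl: Expecting Compound 4

The source may hold more compounds than are shown below. What is called first, only, known or untested is meant among the compounds shown, and "the series" means these compounds.

Measured compounds:
compound 1, `COc1cc(-c2nnc(SCC(=O)Nc3ccc(/C(C)=N/O)cc3)n2-c2ccccc2)cc(OC)c1OC`, gives 66%
compound 2, `CCn1c(SCC(=O)Nc2ccc(/C(C)=N/O)cc2)nnc1-c1cc(OC)c(OC)c(OC)c1`, gives 70%
compound 3, `COc1ccc(-c2nnc(SCC(=O)Nc3ccc(/C(C)=N/O)cc3)n2-c2ccccc2)cc1OC`, gives 77%

All three were tested in a functional assay on the whole organism (strain albino) for inhibition, with Rattus norvegicus as the target, read by paw edema, with stated times of 30 min and 3 h, at a dose of 0.28 mmol/kg by the oral route; a lower number here means less inhibition, a higher number more inhibition at the dose given (going by the name of the read-out). Compound 2 stands second of the three numbers. Its value and that of compound 1 lie within the scatter of each other, and so do its value and that of compound 3, so compound 2 cannot be placed above or below either neighbour with confidence. Among the measured compounds shown here, the only step that reaches beyond the scatter is the one from compound 1 to compound 3.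

Compound 4, `CCn1c(SCC(=O)Nc2ccc(C(C)=O)cc2)nnc1-c1cc(OC)c(OC)c(OC)c1`, differs from compound 2 in a single place: a group of 3 heavy atoms (2 carbon, 1 oxygen; no ring) in place of a group of 4 heavy atoms (2 carbon, 1 nitrogen, 1 oxygen; no ring), on an aromatic carbon. The two measured steps concern other parts of the molecule: a number 4 percentage points higher from compound 1 to compound 2 (within the scatter) and a number 11 percentage points higher from compound 1 to compound 3 (beyond the scatter). Neither involves the group that is exchanged here, so there is no measured guide to what this change does, and the rest of the shared core stays the same. With nothing pointing in either direction, I expect a number 2 percentage points lower from compound 2 to compound 4 (within the scatter), that is, no step beyond the scatter in this assay . My estimate for compound 4 is therefore 68%, expected to fall between 52% and 82%.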

Compound 4, a percentage reported as inhibition, in the whole organism at one dose (the size of the read-out at that dose, not a potency): 54%
Compound 4: the middle estimate sits 14 percentage points above what was measured, within the range that was stated.
By their numbers in this assay, from the lowest: compound 4; then compounds 1, 2 and 3 (each within the scatter of the next, the first and the last beyond it).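

This is the first change shown at this place, an aromatic carbon para to a large group, and in this assay acetyl entering there gives a number 16 percentage points lower from compound 2 to compound 4 (beyond the scatter), so this end of the molecule can shift the reading beyond the scatter. The group that leaves carries 1 hydrogen-bond donor and 2 hydrogen-bond acceptors, while acetyl carries 0 hydrogen-bond donors and 1 hydrogen-bond acceptor, but a single swap cannot show whether those counts, the loss of the nitrogen or something else accounts for the step. Nothing measured here bears on why the number moved.

Only one replacement is shown at this place, so it remains open whether a carboxylic acid, an amine or a longer chain on the same carbon would read closer to compound 2 or to compound 4. From the compounds shown here alone, it is also open whether acetyl would bring a similar step on the cores of compound 1 and compound 3, which carry a phenyl on the aromatic nitrogen where compound 2 has an ethyl.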